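The source may report more compounds than this note shows. Statements on the series, on what has been measured and on what is new or still open speak of the compounds shown alone.

Compound 1 `COc1ccc(-c2nc(C)c(C(=O)CSc3nc(-c4ccc(Cl)cc4)c(C#N)c(=O)[nH]3)s2)cc1`: 63000 nM
Compound 2 `COc1ccc(-c2nc(C)c(C(=O)CSc3nc(-c4ccc(OC)c(OC)c4)c(C#N)c(=O)[nH]3)s2)cc1`: 23300 nM
Compound 3 `COc1ccc(-c2nc(SCC(=O)c3sc(-c4ccccc4)nc3C)[nH]c(=O)c2C#N)cc1OC`: 91800 nM

All three values come from an ADME assay on HEK293 cells (Homo sapiens) for cytotoxicity, read by MTT assay, with a stated time of 48 h; a lower number here means a stronger inhibitor, a higher number a weaker inhibitor. Compound 2, at 23300 nM, has the lowest number of the three, and its gaps to both others lie beyond the scatter. Compound 4 `COc1ccc(-c2nc(C)c(C(=O)CSc3nc(-c4ccc(Cl)c(Cl)c4)c(C#N)c(=O)[nH]3)s2)cc1` has not yet been measured. It differs from compound 2 as follows: 3,4-dichlorophenyl in place of 3,4-dimethoxyphenyl on an aromatic carbon. In words, it carries 3,4-dichlorophenyl in place of 3,4-dimethoxyphenyl on an aromatic carbon.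

The closest evidence is a 2.7-fold lower number from compound 1 to compound 2 (0.43 log units; beyond the scatter), seen with 3,4-dimethoxyphenyl in place of 4-chlorophenyl at that same place. Among the compounds with values here, compound 4 goes back from 3,4-dimethoxyphenyl to a chlorine-bearing group, although no measured compound carries 3,4-dichlorophenyl. The other step, a 3.9-fold higher number from compound 2 to compound 3 (0.60 log units; beyond the scatter), lies elsewhere in the molecule and shows only how large steps in this small set can be. A modest rise is therefore expected, opposite in direction to the step from compound 1.

The estimated change is a 2.1-fold higher number from compound 2 to compound 4 (0.33 log units; beyond the scatter).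

For compound 4 the expected value is 50000 nM, with an estimated range of 20000 nM to 120000 nM.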

Compound 4, half-maximal inhibitory concentration: 45600 nM
Compound 4: middle estimate off by 1.1-fold (0.04 log units), on the high side; low and high end bracket the measured number.
By their numbers in this assay, from the lowest: compounds 2, 4, 1 and 3 (each within the scatter of the next, the first and the last beyond it).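

In this assay, the position accepts this change with a 2.0-fold higher number from compound 2 to compound 4 (0.29 log units; within the scatter), and adding one more chloro to the 4-chlorophenyl group gives a 1.4-fold lower number from compound 1 to compound 4 (0.14 log units; within the scatter). Compound 4 therefore cannot be told apart from either compound 1 or compound 2, even though the earlier comparison of those two, a 2.7-fold lower number from compound 1 to compound 2 (0.43 log units; beyond the scatter), showed a real gap, so the 3,4-dichlorophenyl group does not settle which of them it resembles. Nothing measured here accounts for these numbers.

Still open, going by these compounds, is how this position would respond to a phenyl group carrying an amine or a carboxylic acid. Also open, on these data alone, is whether removing the methoxy group, as in compound 3, would have the same effect with 3,4-dichlorophenyl in place.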